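The source may report more compounds than this note shows. Statements on the series, on what has been measured and on what is new or still open speak of the compounds shown alone.

Measured in a functional assay on HeLa cells (Homo sapiens) for cytotoxicity, read by MTT assay, with a stated time of 48 h; a lower number here means a stronger inhibitor, a higher number a weaker inhibitor:

- compound 1 `CC(C)=CCC/C(C)=C/CC/C(C)=C/CC[C@@H]1[C@@]2(C)CC/C(=N\OCc3cn(-c4cccc(Br)c4)nn3)C(C)(C)[C@@H]2CC[C@@]1(C)O` gives 15700 nM
- compound 2 `CC(C)=CCC/C(C)=C/CC/C(C)=C/CC[C@@H]1[C@@]2(C)CC/C(=N\OCc3cn(-c4ccccc4C#N)nn3)C(C)(C)[C@@H]2CC[C@@]1(C)O` gives 21200 nM
- compound 3 `CC(C)=CCC/C(C)=C/CC/C(C)=C/CC[C@@H]1[C@@]2(C)C/C(=C\c3ccc(OCc4cn(-c5cccc(Br)c5)nn4)cc3)C(=O)C(C)(C)[C@@H]2CC[C@@]1(C)O` gives 37200 nM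

Compounds 1 and 2 share one core; compound 3 carries another, and the difference between the two cores is not broken down here. Within the first pair the only change is 2-cyanophenyl in place of 3-bromophenyl on an aromatic nitrogen, and that change gave a 1.4-fold higher number from compound 1 to compound 2 (0.13 log units; within the scatter), a step that stays within the scatter of the measurement. Compound 3 sits at the high end of the three numbers: against compound 2 its number is within the scatter, against compound 1 it is beyond it.

The compound still to be measured is compound 4 `CC(C)=CCC/C(C)=C/CC/C(C)=C/CC[C@@H]1[C@@]2(C)C/C(=C\c3ccc(OCc4cn(-c5ccccc5C#N)nn4)cc3)C(=O)C(C)(C)[C@@H]2CC[C@@]1(C)O`. It differs from compound 3 by 2-cyanophenyl in place of 3-bromophenyl on an aromatic nitrogen, the same change as that from compound 1 to compound 2, made at a place described in the same words. The expectation for compound 4 in this assay rests on one precedent. That precedent is a 1.4-fold higher number from compound 1 to compound 2 (0.13 log units; within the scatter). The same step is expected to repeat here, so for compound 4 an estimated 1.4-fold higher number from compound 3 to compound 4 (0.15 log units; within the scatter) is taken, acknowledging that a single prior step on a different core is thin ground. On that basis compound 4 is estimated at 52000 nM, with the expected range running from 25000 nM to 110000 nM.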

Compound 4, half-maximal inhibitory concentration: 100000 nM
Compound 4: the middle estimate sits 1.9-fold (0.28 log units) below what was measured; the range from low to high includes it.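

In this assay, putting 2-cyanophenyl in place of 3-bromophenyl on the aromatic nitrogen of the second core gave a 2.7-fold higher number from compound 3 to compound 4 (0.43 log units; beyond the scatter), and the comparison with the same change on the first core does not separate the two steps: the same change on two cores in this assay, a 1.4-fold higher number (0.13 log units; within the scatter) from compound 1 to compound 2 and a 2.7-fold higher number (0.43 log units; beyond the scatter) from compound 3 to compound 4, 2.0-fold (0.30 log units) apart, within the scatter of two such steps. On these two pairs, the change can therefore be carried from one core to the other without any measurable difference in the size of its step, and both steps are printed as higher numbers. This does not show that the change acts identically on every core in the series or that the second core amplifies it: only the second step lies beyond the scatter, the first stays within it, and two pairs set no general rule.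

Going by these compounds, whether an unsubstituted phenyl, a phenyl bearing an amine or a carboxylic acid, or a plain alkyl chain on that nitrogen would also transfer between the two cores remains open. Also open, on these data alone, is how much of the step belongs to the bromine leaving and how much to the nitrile entering, since the two always change together in these compounds.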